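Swapping aryl for arylamino on the shared core

The compounds below may be only part of what the source reports. "The series", "measured", "known", "first", "only" and "open" are said of these compounds alone.

Three compounds sit close together in a functional assay on Jurkat cells (Homo sapiens) for antiproliferative activity, read by MTT assay, with a stated time of 72 h; a lower number here means a stronger inhibitor, a higher number a weaker inhibitor. Compound 1 `COc1ccc(-c2c(C(=O)c3cc(OC)c(OC)c(OC)c3)sc3ccccc23)cc1` gives 1600 nM, compound 2 `COc1cc(C(=O)c2sc3ccccc3c2-c2ccc(SC)cc2)cc(OC)c1OC` gives 1900 nM and compound 3 `COc1ccccc1-c1c(C(=O)c2cc(OC)c(OC)c(OC)c2)sc2ccccc12` gives 2900 nM. Compound 3 therefore stands within the scatter of both others, as the step of a 1.8-fold higher number from compound 1 to compound 3 (0.26 log units; within the scatter) and the step of a 1.5-fold higher number from compound 2 to compound 3 (0.18 log units; within the scatter) show. The remaining step, a 1.2-fold higher number from compound 1 to compound 2 (0.07 log units; within the scatter), also stays within the scatter.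

Compound 4 `COc1ccc(Nc2c(C(=O)c3cc(OC)c(OC)c(OC)c3)sc3ccccc23)cc1` brings a different kind of change: (4-methoxyphenyl)amino in place of 2-methoxyphenyl on an aromatic carbon. In words, this is (4-methoxyphenyl)amino in place of 2-methoxyphenyl on an aromatic carbon, next to the ring atom that bears a large group.

Going by the values given here, no measured step introduces an amino group at this place, so the series offers no direct precedent. The closest evidence is compound 1, which also carries a 4-methoxyphenyl group and gives 1600 nM. The step of a 1.8-fold higher number from compound 1 to compound 3 (0.26 log units; within the scatter) is the only measured link between the 4-methoxyphenyl and 2-methoxyphenyl groups, and it is small. A modest move to a lower number is therefore expected, though the untested amino group leaves the direction uncertain. The expected change is a 2.4-fold lower number from compound 3 to compound 4 (0.38 log units; beyond the scatter). For compound 4 the estimate in this assay is 1200 nM, with an expected range of 250 nM to 5000 nM.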

Compound 4, half-maximal inhibitory concentration: 3500 nM
Beside the measured number, compound 4's estimate is 2.9-fold (0.46 log units) below it; the measured number falls inside the stated range.
By their numbers in this assay, from the lowest: compounds 1, 2, 3 and 4 (each within the scatter of the next, the first and the last beyond it).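

Going by these compounds alone, at this position, on an aromatic carbon of a five-membered aromatic ring with 1 sulfur, (4-methoxyphenyl)amino is the first group that joins its aromatic ring through an amino link, and in this assay the swap from 4-methoxyphenyl gives the only step beyond the scatter, a modest one: a 2.2-fold higher number from compound 1 to compound 4 (0.34 log units; beyond the scatter). The same group cannot be told apart from the other two aryl groups, as a 1.2-fold higher number from compound 3 to compound 4 (0.08 log units; within the scatter) and a 1.8-fold higher number from compound 2 to compound 4 (0.27 log units; within the scatter) show, so the added hydrogen-bond donor comes with a separation from compound 1 only. No data on hand explain this difference.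

The compounds shown leave open whether the amino link or the place of the methoxy group on the outer ring matters more, and a (2-methoxyphenyl)amino group at this position would separate the two. Also open, as far as these compounds go, is how an ether oxygen or a methylene link in place of the amino link would read in this assay, with the same 4-methoxyphenyl ring kept.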